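A Halogen Swap on the Aryl Ketone of Compound 2

The source may report more compounds than this note shows. Statements on the series, on what has been measured and on what is new or still open speak of the compounds shown alone.

The study measured a functional assay on K562 cells (Homo sapiens) for inhibition, read by sulforhodamine B assay, with a stated time of 48 h (on this read-out higher numbers stand for lower toxicity in this test and lower numbers for higher toxicity in this test), for two compounds. Compound 1 `COc1ccc(-c2cc(/C=C/C(=O)c3ccc(N)cc3)[nH]n2)cc1` gives 69700 nM in this assay. Compound 2 `COc1cc(-c2cc(/C=C/C(=O)c3ccc(Cl)c(Cl)c3)[nH]n2)cc(OC)c1OC` is reported in this assay only as a limit of the assay, > 100000 nM, and no number for compound 2 is known beyond that limit (the limit of > 100000 nM in this assay, at which 1 of the 2 values shown sits). Compound 3 `COc1cc(-c2cc(/C=C/C(=O)c3ccc(F)c(F)c3)[nH]n2)cc(OC)c1OC` differs from compound 2 in one place: 3,4-difluorophenyl in place of 3,4-dichlorophenyl on a carbonyl carbon. Among the compounds with values here, no measured pair in this set shows a step of this kind, so there is no measured guide to its size. The step from compound 2 to compound 3 is expected to be small, a number no higher from compound 2 to compound 3 (the limit leaves the size open), nothing beyond the usual scatter. Compound 3 is therefore estimated at 100000 nM, within a range from 40000 nM to 250000 nM, with a fair chance that this assay again reports only a limit.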

Compound 3, concentration lethal to 50% of the cells: > 100000 nM
Compound 3 ended at the assay's limit (the forecaster's own chance of this, stated with the estimate: 55%); the middle value lies on the limit itself.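

No step can be read from compound 2 to compound 3, because each value is a limit and not a number: the limit of > 100000 nM in this assay, at which 2 of the 3 values shown sit. The compounds shown leave open where either compound truly lies, and so what 3,4-difluorophenyl in place of 3,4-dichlorophenyl does on a carbonyl carbon.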